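The source may report more compounds than this note shows. Statements on the series, on what has been measured and on what is new or still open speak of the compounds shown alone.

Measured so far in a functional assay on A549 cells (Homo sapiens) for inhibition, read by sulforhodamine B assay, with a stated time of 48 h; a higher number here means a weaker inhibitor of growth, a lower number a stronger inhibitor of growth
compound 1 `COc1ccc(/C=C/C(=O)C(=Cc2ccc(N(C)C)cc2)C(=O)/C=C/c2ccc(OC)c(OC)c2)cc1OC` gives 2620 nM
compound 2 `COc1ccc(/C=C/C(=O)C(=Cc2cccc(OC)c2OC)C(=O)/C=C/c2ccc(OC)c(OC)c2)cc1OC` gives 670 nM
compound 3 `COc1ccc(OC)c(C=C(C(=O)/C=C/c2ccc(OC)c(OC)c2)C(=O)/C=C/c2ccc(OC)c(OC)c2)c1` gives 530 nM

Compound 3 shares the low, stronger end of this set with compound 2, and the two cannot be told apart: a 1.3-fold lower number from compound 2 to compound 3 (0.10 log units; within the scatter). Compound 4 `COc1ccc(/C=C/C(=O)C(=CO)C(=O)/C=C/c2ccc(OC)c(OC)c2)cc1OC` is still unmeasured. It differs from compound 3 by hydroxy in place of 2,5-dimethoxyphenyl on a double-bonded chain carbon bound to a double-bonded chain carbon, which puts hydroxy in place of 2,5-dimethoxyphenyl. Among the compounds with values here, the only measured changes at this place swap one ring for another, and the largest is a 4.9-fold lower number from compound 1 to compound 3 (0.69 log units; beyond the scatter). None removes the ring, so they are a weak guide to size and direction. The expected change in this assay is a modest rise, an estimated 2.8-fold higher number from compound 3 to compound 4 (0.45 log units; beyond the scatter). For compound 4 the estimated value is 1500 nM, with an expected range from 350 nM to 6000 nM.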

Compound 4, concentration for 50% growth inhibition: > 25000 nM
Compound 4: no number, only a limit (the forecaster's own chance of this, stated with the estimate: 3%); middle value at least 16-fold (1.22 log units) from the limit.
By their numbers in this assay, from the lowest: compounds 3 and 2 (each within the scatter of the next); then compound 1. At a limit, above all of these: compound 4.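

In this assay compound 4 gives > 25000 nM, which is a limit of the assay and not a number. The earlier changes at this place only swapped one ring for another, whereas here the ring leaves and hydroxy enters, and growth inhibition falls away against all three ring-bearing compounds (an at least 47-fold higher number from compound 3 to compound 4 (1.67 log units; beyond the scatter); an at least 37-fold higher number from compound 2 to compound 4 (1.57 log units; beyond the scatter); an at least 9.5-fold higher number from compound 1 to compound 4 (0.97 log units; beyond the scatter)). So at this place, having some aromatic ring counts for more than which of these rings it is.

On these data alone, whether the loss comes from removing the ring or from adding hydroxy remains open. A piperidine ring or a short alkyl chain here could help separate the two.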